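A Second Chlorine Added to Compound 3

The source may report more compounds than this note shows. Statements on the series, on what has been measured and on what is new or still open speak of the compounds shown alone.

Of the compounds shown here, three sharing one core have been measured. Compound 1 `COc1cc2c(Oc3ccc(NC(=O)c4nn(-c5ccccc5)c(=O)cc4C)cc3F)ccnc2cc1OCCCN1CCCC1` gives 120 nM in a functional assay on MKN-45 cells (Homo sapiens) for inhibition, read by MTT assay, with a stated time of 72 h; on this read-out lower numbers stand for stronger inhibition and higher numbers for weaker inhibition. Compound 2 `COc1cc2c(Oc3ccc(NC(=O)c4nn(-c5ccc(Cl)cc5)c(=O)cc4C)cc3F)ccnc2cc1OCCCN1CCCC1` gives 150 nM in this assay; it differs from compound 1 by chloro in place of hydrogen on an aromatic carbon, and the step was a 1.3-fold higher number from compound 1 to compound 2 (0.10 log units; within the scatter). Compound 3 `COc1cc2c(Oc3ccc(NC(=O)c4nn(-c5ccc(Cl)cc5)c(=O)cc4C)cc3F)ccnc2cc1OCCCN1CCCCC1` gives 230 nM in this assay, the step being a 1.5-fold higher number from compound 2 to compound 3 (0.19 log units; within the scatter). The difference between the cores of compound 1 and compound 3 is not broken down here.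

Compound 4 `COc1cc2c(Oc3ccc(NC(=O)c4nn(-c5ccc(Cl)cc5Cl)c(=O)cc4C)cc3F)ccnc2cc1OCCCN1CCCCC1` has not yet been measured. It differs from compound 3 by chloro in place of hydrogen on an aromatic carbon. This is the same kind of change as from compound 1 to compound 2, but the place differs: there the new chloro stood para to a large group, here it stands ortho to a large group and meta to a chloro group. Because the earlier chlorine gave a 1.3-fold higher number from compound 1 to compound 2 (0.10 log units; within the scatter), a step of similar size is expected here, namely a 1.3-fold higher number from compound 3 to compound 4 (0.12 log units; within the scatter). Compound 4 is therefore estimated at 300 nM in this assay, with the likely range running from 150 nM to 600 nM.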

Compound 4, half-maximal inhibitory concentration: 80 nM
The estimate for compound 4 lay 3.8-fold (0.57 log units) above the measured number, and the stated range ends above it.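

In this assay, the change from 4-chlorophenyl to 2,4-dichlorophenyl gave a 2.9-fold lower number from compound 3 to compound 4 (0.46 log units; beyond the scatter). Chloro in place of hydrogen on this aromatic ring therefore cannot be carried from one core to another as a fixed step, since the two cases differ clearly: the same change on two cores in this assay, a 1.3-fold higher number (0.10 log units; within the scatter) from compound 1 to compound 2 and a 2.9-fold lower number (0.46 log units; beyond the scatter) from compound 3 to compound 4, 3.6-fold (0.56 log units) apart, beyond the scatter of two such steps What this does not show is the reason, as the two pairs differ both in the group at the end of the chain, pyrrolidin-1-yl in one and piperidin-1-yl in the other, and in where the new chloro stands, which in compound 4 is ortho to a large group and meta to a chloro group, and a single pair of each kind cannot separate these two differences.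

The compounds shown leave open whether a chloro at this same place would give a similar step with pyrrolidin-1-yl at the end of the chain. They also leave open whether a fluoro or a methyl group at that place would behave as chloro does.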